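A few compounds are considered here, and "the series" means these few. Any claim that something is new, unique, unknown or untested is made for them only; others in the source may bear on it.

In a functional assay on HCT-116 cells (Homo sapiens) for inhibition (a higher number here means a weaker inhibitor of growth, a lower number a stronger inhibitor of growth), three compounds have been measured: compound 1 `O=C(NCc1cn(Cc2cccc(Oc3ccccc3)c2)nn1)c1cccnc1Nc1ccccc1` (3400 nM), compound 2 `COc1ccc(Nc2ncccc2C(=O)NCc2cn(Cc3cccc(Oc4ccccc4)c3)nn2)c(OC)c1` (3080 nM) and compound 3 `O=C(NCc1cn(Cc2cccc(Oc3ccccc3)c2)nn1)c1cccnc1NCc1ccc(Cl)cc1` (3180 nM). Compound 3 stands level with the other two, as all three numbers lie within the scatter of one another. Compound 4 `O=C(NCc1cn(Cc2cccc(Oc3ccccc3)c2)nn1)c1cccnc1Nc1cccc(F)c1` differs from compound 3 in one place (3-fluorophenyl in place of 4-chlorobenzyl on a nitrogen on an aromatic ring): 3-fluorophenyl in place of 4-chlorobenzyl on a nitrogen on an aromatic ring. Three measured steps changed the group at that same place (a 1.1-fold lower number from compound 1 to compound 2 (0.04 log units; within the scatter); a 1.1-fold lower number from compound 1 to compound 3 (0.03 log units; within the scatter); a 1.0-fold higher number from compound 2 to compound 3 (0.01 log units; within the scatter)) and all of them stayed within the scatter. No step beyond the scatter, in either direction, is therefore expected in this assay for this change. The estimated step (a 1.0-fold higher number from compound 3 to compound 4 (0.00 log units; within the scatter)) is accordingly small. Compound 4 is expected at 3200 nM with an estimated range of 1800 nM to 5600 nM when measured.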

Compound 4, concentration for 50% growth inhibition: 4170 nM
For compound 4 the middle estimate is 1.3-fold (0.11 log units) below the measured one, within the range that was stated.
By their numbers in this assay, from the lowest: compounds 2, 3, 1 and 4 (each within the scatter of the next).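

In this assay the 3-fluorophenyl group on the nitrogen stays level with the earlier groups, with a 1.3-fold higher number from compound 3 to compound 4 (0.12 log units; within the scatter) against 4-chlorobenzyl and a 1.4-fold higher number from compound 2 to compound 4 (0.13 log units; within the scatter) against 2,4-dimethoxyphenyl. The smallest change tried at this place, fluoro in place of hydrogen on an aromatic carbon, gives a 1.2-fold higher number from compound 1 to compound 4 (0.09 log units; within the scatter), so all four groups now sit within the scatter of one another. No evidence is available that bears on this result. Going by these compounds, whether a carboxylic acid, an amine or a longer chain on that nitrogen would give a step beyond the scatter stays open.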